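Swapping an ether for a thioether on a purine-like core

This account rests on a few compounds, and the source may have more. Where it says the series, first, only, none or still open, it means among the compounds named here.

Compound 1 `CC(C)CSc1nc(N)nc2c1ncn2/C=C1/CC1(CO)CO`: "not determined" (no result reported) in an ADME assay on MOLT-3 cells (Homo sapiens) for cytotoxicity, with a stated time of 7 days; a higher number here means that more compound is tolerated, a lower number that less compound is tolerated
Compound 2 `COCCOc1nc(N)nc2c1ncn2/C=C1/CC1(CO)CO`: > 20000 nM in this assay

Two compounds share the same core and differ only in the group attached to one aromatic carbon. For compound 1 no result was reported in this assay. In this assay compound 2 gives > 20000 nM, which is a limit of the assay and not a number. This means compound 2 sits at the limit of > 20000 nM in this assay, at which 1 of the 2 values shown sits, so its true value is known only to lie beyond that point.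

Compound 3 `CCCCSc1nc(N)nc2c1ncn2/C=C1/CC1(CO)CO` has not yet been measured. It differs from compound 2 by butylsulfanyl in place of 2-methoxyethoxy on an aromatic carbon. Among the compounds with values here, since no measured pair of compounds separates the effect of this change, no step size can be read from the data. Compound 2 already tolerates the highest concentration tested, so the expectation is that compound 3 behaves much the same and that a number no higher from compound 2 to compound 3 (the limit leaves the size open) is a step of no real size beyond the usual scatter. Compound 3 is therefore estimated at 20000 nM, with a likely range from 8000 nM to 50000 nM, and most probably reported again only as a limit.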

Compound 3, half-maximal cytotoxic concentration: > 20000 nM
Compound 3 ended at the assay's limit (the forecaster's own chance of this, stated with the estimate: 70%); the middle value sits exactly at the limit.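

In this assay compound 2 and compound 3 are both recorded only as limits of the assay, so no step between them can be read: the limit of > 20000 nM in this assay, at which 2 of the 3 values shown sit.

The compounds shown leave open how far compound 2 and compound 3 truly lie apart, and whether butylsulfanyl in place of 2-methoxyethoxy on an aromatic carbon changes how much compound is tolerated.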